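Benzyl-type nitrogen substituent on the shared core

The source may hold more compounds than are shown below. What is called first, only, known or untested is meant among the compounds shown, and "the series" means these compounds.

Measured compounds:
compound 1 `CCCCn1ccc2cc(/C(C)=C/C(=O)Nc3ccccc3OCCCC(=O)O)ccc21`, 43 nM
compound 2 `C/C(=C\C(=O)Nc1ccccc1OCCCC(=O)O)c1ccc2c(ccn2CC(C)C)c1`, 160 nM
compound 3 `CCCCC(CCCC)n1ccc2cc(/C(C)=C/C(=O)Nc3ccccc3OCCCC(=O)O)ccc21`, 21 nM

Compound 1 is tested in an assay on Prostate gland for inhibition of steroid 5-alpha-reductase (Rattus norvegicus) (on this read-out lower numbers stand for stronger inhibition and higher numbers for weaker inhibition), where it gives 43 nM, the second highest of the three numbers: compound 3 lies below it by a 2.0-fold lower number from compound 1 to compound 3 (0.31 log units; beyond the scatter), compound 2 above it by a 3.7-fold higher number from compound 1 to compound 2 (0.57 log units; beyond the scatter). The unmeasured compound 4 `C/C(=C\C(=O)Nc1ccccc1OCCCC(=O)O)c1ccc2c(ccn2Cc2ccccc2C)c1` differs from compound 1 by 2-methylphenyl in place of propyl on a saturated chain carbon bound to an aromatic nitrogen; cut one bond further out, this reads butyl to 2-methylbenzyl. Going by the values given here, two measured steps bear on it, both on the same aromatic nitrogen. Going to a branched, shorter chain gave a 3.7-fold higher number from compound 1 to compound 2 (0.57 log units; beyond the scatter), while a longer branched chain gave a 2.0-fold lower number from compound 1 to compound 3 (0.31 log units; beyond the scatter). A 2-methylbenzyl group is larger than butyl, like the change in compound 3, but its branching sits at the same carbon as in compound 2; the data show no change of this kind directly, so the direction is uncertain. Compound 4 is therefore expected at about 35 nM, within 12 nM to 110 nM, a step of a 1.2-fold lower number from compound 1 to compound 4 (0.09 log units; within the scatter) estimated as no more than modest in this assay.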

Compound 4, half-maximal inhibitory concentration: 69 nM
Beside the measured number, compound 4's estimate is 2.0-fold (0.29 log units) below it; low and high end bracket the measured number.
By their numbers in this assay, from the lowest: compound 3; then compounds 1 and 4 (each within the scatter of the next); then compound 2.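

In this assay, an aromatic ring can be carried on the saturated chain carbon bound to the aromatic nitrogen with no change beyond the scatter, as 2-methylphenyl in place of propyl gives a 1.6-fold higher number from compound 1 to compound 4 (0.21 log units; within the scatter) and leaves the two compounds indistinguishable. The benzyl-type group also falls inside the span set by the two branched alkyl groups, with a 2.3-fold lower number from compound 2 to compound 4 (0.37 log units; beyond the scatter) on one side and a 3.3-fold higher number from compound 3 to compound 4 (0.52 log units; beyond the scatter) on the other, so a ring at this position is tolerated without matching 1-butylpentyl. No evidence at hand explains this ordering of the nitrogen substituents.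

On these data alone, what plain benzyl would give at this nitrogen remains open, as does the effect of moving the methyl elsewhere on the ring. So does the outcome for a benzyl group carrying an amine or a carboxylic acid.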